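Working notes: the step from compound 1 to compound 3

The compounds below may be only part of what the source reports. "The series", "measured", "known", "first", "only" and "open" are said of these compounds alone.

compound 1 `Cc1nn(C)c2nc(NNC(=O)Nc3cc(Cl)nc(Cl)c3)cc(C3CC3)c12`: 67700 nM
compound 2 `Cn1ncc2c(-c3ccc(F)cc3)cc(NNC(=O)Nc3cc(Cl)nc(OCCF)c3)nc21`: 37200 nM

Both numbers come from a functional assay on HCT-116 cells (Homo sapiens) for cytotoxicity, read by MTT assay, with a stated time of 48 h, in the presence of a further agent that is not named here; a lower number here means that less compound is needed, a higher number that more compound is needed for the effect. In this assay compound 1 gives 67700 nM and compound 2 gives 37200 nM; the two values lie within the usual scatter of each other, so compound 1 is not set apart from compound 2 on these numbers. Within the data shown here, no step between measured compounds that differ in one place is known.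

Compound 3 `Cc1nn(C)c2nc(NNC(=O)Nc3cc(Cl)nc(Cl)c3)cc(-c3ccc(F)cc3)c12` differs from compound 1 by 4-fluorophenyl in place of cyclopropyl on an aromatic carbon. Compound 2 carries the same 4-fluorophenyl but differs from compound 1 elsewhere as well, so its value cannot be read as the size of this change. The step is therefore expected to be a 1.5-fold lower number from compound 1 to compound 3 (0.18 log units; within the scatter), that is, none beyond the scatter. In this assay compound 3 is estimated at 45000 nM, with a range from 15000 nM to 150000 nM.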

Compound 3, half-maximal effective concentration: 25200 nM
Beside the measured number, compound 3's estimate is 1.8-fold (0.25 log units) above it; the measured number falls inside the stated range.
By their numbers in this assay, from the lowest: compounds 3, 2 and 1 (each within the scatter of the next, the first and the last beyond it).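

Among these compounds, replacing cyclopropyl with 4-fluorophenyl on this aromatic carbon, opposite the ring nitrogen, gives a 2.7-fold lower number from compound 1 to compound 3 (0.43 log units; beyond the scatter) in this assay; this is the first change that can be read at a single position. It shows that this assay responds to the group at this position, although the step is modest and compound 3 still gives 25200 nM. No measurement available here accounts for the step.

Still open, on these data alone, is whether the step belongs to the aromatic ring itself or to its fluorine, a question that plain phenyl at this position would address. Also open, as far as these compounds go, is how far the position tolerates other groups, such as a 4-aminophenyl, a 4-carboxyphenyl or a longer alkyl chain.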